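A few compounds are considered here, and "the series" means these few. Any claim that something is new, unique, unknown or untested is made for them only; others in the source may bear on it.

Measured so far:
compound 1 `C=C[C@@](C)(CC[C@H]1C(C)=CC[C@H]2C(C)(C)CCC[C@]12C)O[C@@H]1O[C@H](C)[C@H](O)[C@H](O)[C@H]1O` — 3.5 ug/mL
compound 2 `C=C[C@@](C)(CC[C@H]1C(C)=CC[C@H]2C(C)(C)CCC[C@]12C)O[C@@H]1O[C@H](C)[C@H](O)[C@H](OC(C)=O)[C@H]1O` — 3.5 ug/mL
compound 3 `C=C[C@@](C)(CC[C@@H]1[C@@]2(C)CCCC(C)(C)[C@@H]2CC[C@@]1(C)O)O[C@H]1O[C@H](C)[C@H](O)[C@@H](O)[C@@H]1O` — > 5 ug/mL

For the measured compounds named here, in a functional assay on SK-MEL-2 cells (Homo sapiens) for cytotoxicity, read by sulforhodamine B assay (a higher number here means that more compound is needed for the effect, a lower number that less compound is needed), compound 1 gives 3.5 ug/mL and compound 2 gives 3.5 ug/mL; the one step measured so far, no change at the digits printed from compound 1 to compound 2 (within the scatter), is the only change with a number on both sides. For compound 3 this assay gives only a limit, > 5 ug/mL, so its place is known just as a bound the limit of > 5 ug/mL in this assay, at which 1 of the 3 values shown sits, and not as a value.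

The next compound, compound 4 `C=C[C@@](C)(CC[C@@H]1[C@@]2(C)CCCC(C)(C)[C@@H]2CC[C@@]1(C)O)O[C@@H]1O[C@H](C)[C@H](O)[C@H](O)[C@H]1O`, keeps the core of compound 3 and differs from it as follows: the two compounds have the same atoms and bonds and differ only in configuration as drawn: 3 of 10 stereo elements differ; a stereocentre at a saturated ring carbon is drawn R in compound 3 and S in compound 4; a stereocentre at a saturated ring carbon is drawn R in compound 3 and S in compound 4; a stereocentre at a saturated ring carbon is drawn S in compound 3 and R in compound 4. Going by the values given here, the sugar as drawn in compound 4 matches that of compound 1 and compound 2, while the core is that of compound 3, so no measured step covers this change directly; the acetylation step from compound 1 to compound 2 tells nothing about a change in configuration.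

With compound 3 itself only at a bound, a step is expected to be small or not resolved, a number no higher from compound 3 to compound 4 (the limit leaves the size open), and compound 4 is estimated at 5 ug/mL in this assay, within 2.5 ug/mL to 10 ug/mL, with a real chance that again only a limit is reported.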

Compound 4, concentration for half-maximal effect: > 5 ug/mL
Compound 4 was reported as a limit; the forecaster's own chance of this, stated with the estimate: 50%; the middle value sits exactly at the limit.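

No step can be read between compound 3 and compound 4, as both are reported only as a limit in this assay: the limit of > 5 ug/mL in this assay, at which 2 of the 4 values shown sit.

The compounds shown leave open whether the three differing stereocentres alter the concentration needed in this assay at all, and if so in which direction and by how much.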